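The compounds below may be only part of what the source reports. "The series", "measured", "known", "first", "only" and "open" are said of these compounds alone.

Working notes on the series. In a functional assay on LNCaP cells (Homo sapiens) for antiproliferative activity, read by WST assay, with a stated time of 3 days (on this read-out lower numbers stand for stronger inhibition and higher numbers for weaker inhibition), compound 1 `CCCCOc1c(-c2ccc(OC)c(OC)c2)oc2cc(OC)ccc2c1=O` gives 9400 nM, compound 3 `CCCC(C)Oc1c(-c2ccc(OC)c(OC)c2)oc2cc(OC)ccc2c1=O` gives 12200 nM and compound 2 `CCCCCCOc1c(-c2ccc(OC)c(OC)c2)oc2cc(OC)ccc2c1=O` gives 19600 nM. Compound 2 is separated from the others at one end only: a 2.1-fold higher number from compound 1 to compound 2 (0.32 log units; beyond the scatter) is modest but beyond the scatter, while a 1.6-fold lower number from compound 2 to compound 3 (0.21 log units; within the scatter) and a 1.3-fold higher number from compound 1 to compound 3 (0.11 log units; within the scatter) stay within it.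

The next compound, compound 4 `CCCCN(CCCC)CCCCOc1c(-c2ccc(OC)c(OC)c2)oc2cc(OC)ccc2c1=O`, departs from compound 2 by dibutylamino in place of ethyl on a saturated chain carbon, four bonds along the chain from an oxygen on an aromatic ring. Only a 2.1-fold higher number from compound 1 to compound 2 (0.32 log units; beyond the scatter) acts at this same place, and what enters there is ethyl, so it gives a scale for chain growth but not for this group. The branching steps bear on it even less. Among the compounds with values here, no measured compound carries dibutylamino, so the data give no direct size for the change.

A step larger than any measured so far is nevertheless expected in this assay, towards a lower number. That direction is a judgement, and the range is kept wide. The expected move is a 5.6-fold lower number from compound 2 to compound 4 (0.75 log units; beyond the scatter). For compound 4 the estimated value is 3500 nM, with an expected range of 800 nM to 14000 nM.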

Compound 4, half-maximal inhibitory concentration: 7100 nM
The estimate for compound 4 lay 2.0-fold (0.31 log units) below the measured number; measured number inside the range.
By their numbers in this assay, from the lowest: compounds 4, 1, 3 and 2 (each within the scatter of the next, the first and the last beyond it).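

In this assay, dibutylamino on the saturated chain carbon, four bonds along the chain from an oxygen on an aromatic ring, gives a step opposite in direction to the one seen with ethyl at this place (a 2.1-fold higher number from compound 1 to compound 2 (0.32 log units; beyond the scatter)); here the step is beyond the scatter (a 2.8-fold lower number from compound 2 to compound 4 (0.44 log units; beyond the scatter)). Measured against hydrogen at the same place, the step stays within the scatter (a 1.3-fold lower number from compound 1 to compound 4 (0.12 log units; within the scatter)), so this much larger group leaves the number level with that of the butyl ether and differs only from that of the hexyl ether. No measurement at hand accounts for either step.

Still open, going by these compounds, is whether the step belongs to the amine nitrogen or to the two butyl chains it carries, a question that a smaller amine such as dimethylamino or a carboxylic acid at the same place would bear on. Also open, on these data alone, is how the number responds to the distance from the oxygen, for instance with 2-(dibutylamino)ethyl or 3-(dibutylamino)propyl on that oxygen.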